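Cytotoxicity notes on two measured analogues and one pending

A few compounds are considered here, and "the series" means these few. Any claim that something is new, unique, unknown or untested is made for them only; others in the source may bear on it.

Measured compounds:
- compound 1 `O=C1Nc2ccccc2/C1=N/NC(=S)N1CCCCC1` — > 25000 nM
- compound 2 `CCCN(CCC)C(=S)N/N=C1/C(=O)Nc2ccccc21` — > 25000 nM

In an ADME assay on RD cells (Homo sapiens) for cytotoxicity (on this read-out lower numbers stand for higher toxicity in this test and higher numbers for lower toxicity in this test), compound 1 gives > 25000 nM, which is the limit of this assay and not a number. Compound 2 gives > 25000 nM in this assay, again a limit. For the measured compounds named here, compound 1 therefore has no measured number to stand on; it sits at the limit of > 25000 nM in this assay, at which 2 of the 2 values shown sit, together with the only other compound tested. Going by the values given here, with both values at the limit, no step between compound 1 and compound 2 can be sized, and nothing within the measured pair tells whether the change at the thiocarbonyl carbon moves the read-out at all.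

Compound 3 `O=C1Nc2ccccc2/C1=N/NC(=S)Nc1ccccc1` is not yet measured in this assay. It differs from compound 1 by anilino in place of piperidin-1-yl on a thiocarbonyl carbon. Among the compounds with values here, the starting point is itself a limit, and no measured step exists. The step that the limit leaves unreadable from compound 1 to compound 3 in this assay is expected to be none beyond the scatter, with the read-out more likely to return a further limit than a number. Compound 3 is estimated at 30000 nM in this assay, within the range 8000 nM to 100000 nM.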

Compound 3, half-maximal cytotoxic concentration: > 25000 nM
Compound 3: a limit, no number; the forecaster's own chance of this, stated with the estimate: 65%; the middle value is on the limit's open side.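

In this assay compound 3 gives > 25000 nM, which is a limit and not a number. For the compounds shown here, no step from compound 1 to compound 3 can be read, because the values stand at a shared limit: the limit of > 25000 nM in this assay, at which 3 of the 3 values shown sit. The compounds shown leave open whether any change on the thiocarbonyl carbon moves this read-out at all.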